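Swapping propyl for ethoxy on the anilino ring

This account rests on a few compounds, and the source may have more. Where it says the series, first, only, none or still open, it means among the compounds named here.

Compound 3 `CCCc1ccc(NC2=CC(=O)c3nc4n(c3C2=O)[C@H]2OC[C@@H](O)[C@H]2OC4)cc1` gives 4660 nM in a functional assay on MCF7 cells (Homo sapiens) for inhibition, read by sulforhodamine B assay; a lower number here means a stronger inhibitor, a higher number a weaker inhibitor. Compound 2 `O=C1C=C(Nc2cccc(Cl)c2)C(=O)c2c1nc1n2[C@H]2OC[C@@H](O)[C@H]2OC1` gives 4720 nM in this assay, and the two numbers sit side by side: a 1.0-fold lower number from compound 2 to compound 3 (0.01 log units; within the scatter). Compound 1 `O=C1C=C(NCc2ccccc2)C(=O)c2c1nc1n2[C@H]2OC[C@@H](O)[C@H]2OC1` reaches only the limit > 8000 nM in this assay, which is the limit of > 8000 nM in this assay, at which 1 of the 3 values shown sits. From that limit the two aryl analogues give an at least 1.6-fold lower number from compound 1 to compound 2 (0.22 log units; that floor lies within the scatter) and an at least 1.7-fold lower number from compound 1 to compound 3 (0.23 log units; that floor lies within the scatter), both floors lying within the scatter. Compound 4 `CCOc1ccc(NC2=CC(=O)c3nc4n(c3C2=O)[C@H]2OC[C@@H](O)[C@H]2OC4)cc1` differs from compound 3 in one place: ethoxy in place of propyl on an aromatic carbon. Cut one bond further out, the change reads 4-propylphenyl to 4-ethoxyphenyl. Within the data shown here, the only measured step that bears on it is the one between the two aryl substituents, from compound 2 to compound 3, which stayed within the scatter; the benzyl-to-aryl steps concern a different part and are only floors. With nothing in the data pointing in either direction, no step beyond the scatter is expected. The step expected in this assay is a 1.0-fold lower number from compound 3 to compound 4 (0.01 log units; within the scatter). Compound 4 is accordingly estimated at 4600 nM, within a range from 1800 nM to 11000 nM.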

Compound 4, half-maximal inhibitory concentration: 1430 nM
For compound 4 the middle estimate is 3.2-fold (0.51 log units) above the measured one, and the stated range ends above it.
By their numbers in this assay, from the lowest: compound 4; then compounds 3 and 2 (each within the scatter of the next). At a limit, above all of these: compound 1.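

In this assay, the group on the aromatic carbon para to a large group does make a difference: exchanging propyl for ethoxy gives a 3.3-fold lower number from compound 3 to compound 4 (0.51 log units; beyond the scatter), although the two groups hold the same number of heavy atoms and differ in that ethoxy carries an oxygen and a hydrogen-bond acceptor where propyl has neither. The aryl groups no longer all read alike, for the change from 3-chlorophenyl to 4-ethoxyphenyl gives a 3.3-fold lower number from compound 2 to compound 4 (0.52 log units; beyond the scatter), whereas the earlier aryl pair, compound 2 and compound 3, showed no separation. The step from benzyl to 4-ethoxyphenyl, an at least 5.5-fold lower number from compound 1 to compound 4 (0.74 log units; beyond the scatter), is the first from compound 1 to clear the scatter, yet compound 1 stands at a limit and the step remains a floor: the limit of > 8000 nM in this assay, at which 1 of the 4 values shown sits.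

Whether the oxygen alone goes with the step stays open, since methoxy, propoxy and an amine on this carbon are not among the compounds shown. Nothing measured here gives a reason for the step from propyl to ethoxy.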